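The compounds below may be only part of what the source reports. "The series", "measured", "known", "first", "only" and "open" are said of these compounds alone.

Working notes on the series. In a functional assay on HFF cells (Homo sapiens) for cytotoxicity (a lower number here means a stronger inhibitor, a higher number a weaker inhibitor), compound 1 `CCCCOC[C@H]1O[C@@H](n2c(Cl)nc3cc(Cl)c(Cl)cc32)[C@H](OC(C)=O)[C@@H]1OC(C)=O` gives 66000 nM, and compound 2 `CC(=O)OC1C(CF)OC(n2c(Cl)nc3cc(Cl)c(Cl)cc32)C1OC(C)=O` gives 32000 nM. Compound 2 therefore holds the lower of the two numbers, with the gap to compound 1 lying just beyond the scatter.

The next compound to be read is compound 3 `CC(=O)OC1C(CN=[N+]=[N-])OC(n2c(Cl)nc3cc(Cl)c(Cl)cc32)C1OC(C)=O`, which carries azido in place of fluoro on a saturated chain carbon bound to a saturated ring carbon. This is a change from fluoromethyl to azidomethyl.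

Among the compounds with values here, the series offers no measured one-place step to serve as a precedent, so the expectation in this assay is of no change beyond the scatter and no firm direction. The estimated step of a 1.1-fold higher number from compound 2 to compound 3 (0.04 log units; within the scatter) is accordingly small. For compound 3 the expected value is 35000 nM, with an estimated range of 12000 nM to 90000 nM.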

Compound 3, half-maximal inhibitory concentration: 32000 nM
Estimate against measurement, compound 3: 1.1-fold (0.04 log units) above; measured number inside the range.
By their numbers in this assay, from the lowest: compounds 2 and 3 (each within the scatter of the next); then compound 1.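

Within the data shown here, the first one-place reading at this position, a saturated chain carbon bound to a saturated ring carbon, comes with azido in place of fluoro: in this assay there is no change at the digits printed from compound 2 to compound 3 (within the scatter). Fluoromethyl and azidomethyl cannot be told apart in this read-out, even though the entering azido brings 3 heavy atoms where the leaving fluoro had 1. No measurement at hand bears on the reason for this result.

Still open, as far as these compounds go, is whether this flat reading extends beyond these two groups, for instance to an amine or a carboxylic acid on the same saturated chain carbon. Also open, from the compounds shown here alone, is whether the same step would read alike with free hydroxyl groups in place of the acetate esters on the shared core.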